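Swapping Ethynyl for Thiophen-3-yl on a Nucleoside Core

This account rests on a few compounds, and the source may have more. Where it says the series, first, only, none or still open, it means among the compounds named here.

Of the compounds shown here, three sharing a ribose-bearing bicyclic core have been measured in a functional assay on HCT-116 cells (Homo sapiens), read by MTT assay, with a stated time of 72 h; on this read-out higher numbers stand for weaker inhibition and lower numbers for stronger inhibition. Compound 1, `Nc1nc(N)c2c(-c3cc4ccccc4o3)cn([C@@H]3O[C@H](CO)[C@@H](O)[C@H]3O)c2n1`, carries a benzofuran-2-yl group and two amino groups and gives 14000 nM. Compound 2, `C#Cc1cn([C@@H]2O[C@H](CO)[C@@H](O)[C@H]2O)c2ncnc(OC)c12`, carries an ethynyl group and a methoxy group and gives 5140 nM. Compound 3, `C#Cc1cn([C@@H]2O[C@H](CO)[C@@H](O)[C@H]2O)c2ncnc(N(C)C)c12`, replaces the methoxy with dimethylamino and gives 290 nM. Among these three, compound 2 stands second highest: compound 1 gives a higher number, while the step of an 18-fold lower number from compound 2 to compound 3 (1.25 log units; beyond the scatter) shows how much lower compound 3 lies.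

Compound 4, `COc1ncnc2c1c(-c1ccsc1)cn2[C@@H]1O[C@H](CO)[C@@H](O)[C@H]1O`, is now to be measured in this assay. It differs from compound 2 in one place: thiophen-3-yl in place of ethynyl on an aromatic carbon. For the measured compounds named here, no measured step covers this exact exchange. Going by the values given here, the only compound with an aromatic ring in that position is compound 1, whose benzofuran-2-yl group sits on a different core and which gives the highest number of the three, so the pair of compound 1 and compound 2 hints that an aryl group there does not bring a lower number. The estimate for compound 4 is therefore a somewhat higher number than compound 2, the expected step being a 1.6-fold higher number from compound 2 to compound 4 (0.19 log units; within the scatter), with wide uncertainty. Compound 4 is estimated at 8000 nM, in a range from 2000 nM to 30000 nM.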

Compound 4, half-maximal inhibitory concentration: 140 nM
Estimate against measurement, compound 4: 57-fold (1.76 log units) above, outside the stated range (below it).
By their numbers in this assay, from the lowest: compound 4; then compound 3; then compound 2; then compound 1.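

In this assay, the place on the aromatic carbon two ring bonds from the ring nitrogen proves far from indifferent to what it carries: with the methoxy group held constant, thiophen-3-yl in place of ethynyl gives a 37-fold lower number from compound 2 to compound 4 (1.56 log units; beyond the scatter) and so shows that an aromatic ring can sit here with a much lower number. For the compounds shown here, this step is the first direct reading of this place, since compound 1 differs from compound 2 in more than one place and its high number therefore says nothing firm about an aromatic ring on the shared core. No measurement shown accounts for the size of this step, so the result stands as an observation without an explanation.

What the compounds shown leave open is whether thiophen-3-yl and dimethylamino can be joined on one compound, and whether the number would then fall further than with either group alone. Nor do they tell whether this result is particular to thiophen-3-yl or extends to other groups at the same place, such as phenyl, furan-2-yl, or a longer chain ending in an amine.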